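Moving the Ring Oxygen in a Glutamate Receptor Modulator Series

The source may hold more compounds than are shown below. What is called first, only, known or untested is meant among the compounds shown, and "the series" means these compounds.

Compound 1: `CCC(=O)N1CCc2nc(C#Cc3ccccc3)sc2C1` gives > 10000 nM, which is a limit of the assay and not a number.
Compound 2: `O=C(C1CCCO1)N1CCc2nc(C#Cc3ccccc3)sc2C1` gives 790 nM.
Compound 3: `O=C(C1CCOCC1)N1CCc2nc(C#Cc3ccccc3)sc2C1` gives 290 nM.

These values come from an assay on HEK293 cells for positive allosteric modulation of metabotropic glutamate receptor 5 (Homo sapiens), read by FLIPR, with a stated time of 1 h; on this read-out higher numbers stand for an effect only at larger amounts of compound and lower numbers for an effect already at smaller amounts. Compound 3 has the lowest number of the two that are numbers; its nearest neighbour is compound 2, and the difference a 2.7-fold lower number from compound 2 to compound 3 (0.44 log units; beyond the scatter) lies beyond the scatter. On these data alone, the steps of an at least 12-fold lower number from compound 1 to compound 2 (1.10 log units; beyond the scatter) and an at least 34-fold lower number from compound 1 to compound 3 (1.53 log units; beyond the scatter) are large, but each starts from a limit (the limit of > 10000 nM in this assay, at which 1 of the 3 values shown sits), so their true size is unknown.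

Compound 4 is `O=C(C1CCCCO1)N1CCc2nc(C#Cc3ccccc3)sc2C1`. It differs from compound 3 in one place: oxan-2-yl in place of oxan-4-yl on a carbonyl carbon. The step that bears on this is a 2.7-fold lower number from compound 2 to compound 3 (0.44 log units; beyond the scatter), where a five-membered ring attached at its 2-position gave way to a six-membered ring attached at its 4-position. Compound 4 keeps the six-membered ring but takes the 2-position attachment, so the change is expected to be modest, with the number expected to rise: a 1.7-fold higher number from compound 3 to compound 4 (0.24 log units; within the scatter). Compound 4 is estimated at 500 nM, with a range from 200 nM to 1500 nM.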

Compound 4, half-maximal effective concentration: 320 nM
For compound 4 the middle estimate is 1.6-fold (0.19 log units) above the measured one; low and high end bracket the measured number.
By their numbers in this assay, from the lowest: compounds 3 and 4 (each within the scatter of the next); then compound 2. At a limit, above all of these: compound 1.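

With the six-membered ring kept, changing where it is attached to the carbonyl carbon makes no readable difference in this assay: the step is a 1.1-fold higher number from compound 3 to compound 4 (0.04 log units; within the scatter). With the attachment kept at the 2-position, enlarging oxolan-2-yl to oxan-2-yl gives a 2.5-fold lower number from compound 2 to compound 4 (0.39 log units; beyond the scatter), so among these compounds the earlier step of a 2.7-fold lower number from compound 2 to compound 3 (0.44 log units; beyond the scatter) goes with ring size and not with the attachment point. The step of an at least 31-fold lower number from compound 1 to compound 4 (1.49 log units; beyond the scatter) cannot be read as a size, because it starts from a limit of compound 1: the limit of > 10000 nM in this assay, at which 1 of the 4 values shown sits.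

On these data alone, whether the ring oxygen matters at all stays open, and a cyclohexyl ring on the same carbonyl carbon would test this. An oxan-3-yl group would complete the set of attachment points on the six-membered ring.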